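Swapping the amide terminus of a bis-sulfonamide piperidine

This account rests on a few compounds, and the source may have more. Where it says the series, first, only, none or still open, it means among the compounds named here.

Of the compounds shown here, three have been measured in a functional assay on MIA PaCa-2 cells (Homo sapiens) for inhibition, read by MTT assay, with a stated time of 7 days; on this read-out lower numbers stand for stronger inhibition and higher numbers for weaker inhibition. Compound 1 `CCN(CC)S(=O)(=O)c1ccc(S(=O)(=O)N2CCC[C@@H](C(=O)NC3CN(C(=O)C4CC4)C3)C2)cc1` gives 2800 nM, the second highest of the three numbers. Compound 2 `CCOC(=O)[C@H]1CCN(S(=O)(=O)c2ccc(S(=O)(=O)N(CC)CC)cc2)C1`, an ester, gives 29200 nM, the highest number of the set. Compound 3 `CC(C)c1noc(N2CCN(C(=O)[C@@H]3CCCN(S(=O)(=O)c4ccc(S(=O)(=O)NC(C)(C)C)cc4)C3)CC2)n1`, which carries a piperazine bearing an oxadiazole on its amide carbonyl together with a tert-butyl sulfonamide, gives 300 nM; on these numbers compound 3 stands well apart from compound 1, and compound 1 in turn stands well apart from compound 2, both gaps lying beyond the usual scatter.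

Compound 4 `CCN(CC)S(=O)(=O)c1ccc(S(=O)(=O)N2CCC[C@@H](C(=O)N3CCN(c4nc(C)no4)CC3)C2)cc1` has not yet been measured. It keeps the diethyl sulfonamide and the shared core of compound 1 and differs only in the amide terminus: 4-(3-methyl-1,2,4-oxadiazol-5-yl)piperazin-1-yl in place of (1-(cyclopropylcarbonyl)azetidin-3-yl)amino on a carbonyl carbon. For the measured compounds named here, no measured pair here isolates exactly this exchange, so the size of the step can only be expected, not read off.

Compound 4 is expected to come in with a lower number than compound 1, because compound 3, whose amide also ends in a piperazine carrying a 1,2,4-oxadiazole, gives 300 nM. The expected step of a 4.0-fold lower number from compound 1 to compound 4 (0.60 log units; beyond the scatter) would therefore fall beyond the scatter. The estimate for compound 4 in this assay is 700 nM, with a range from 200 nM to 2500 nM.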

Compound 4, half-maximal inhibitory concentration: 250 nM
The estimate for compound 4 lay 2.8-fold (0.45 log units) above the measured number; low and high end bracket the measured number.
By their numbers in this assay, from the lowest: compounds 4 and 3 (each within the scatter of the next); then compound 1; then compound 2.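

For the compounds shown here, until now, no measured pair isolated the amide terminus, and this result shows that this place alone can move the number a long way. With the diethyl sulfonamide and the shared core held unchanged, placing 4-(3-methyl-1,2,4-oxadiazol-5-yl)piperazin-1-yl on the carbonyl carbon in place of (1-(cyclopropylcarbonyl)azetidin-3-yl)amino gives an 11-fold lower number from compound 1 to compound 4 (1.05 log units; beyond the scatter) in this assay and is a large step. The exchange alters the ring systems and removes the hydrogen-bond donor while adding hydrogen-bond acceptors, and nothing available explains the size of the step or assigns it to any one of these differences.

The compounds shown leave open whether the step belongs to the piperazine, to the 3-methyl-1,2,4-oxadiazole or only to the two together, a question that a piperazine carrying an acetyl group or a pyridine in place of the oxadiazole would help to separate. They also leave open how the amide terminus behaves on a simple piperidine amide, or with a methyl group on the amide nitrogen of compound 1.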